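Formylhydroxylamine series: sec-butyl to isobutyl exchange

The compounds below may be only part of what the source reports. "The series", "measured", "known", "first", "only" and "open" are said of these compounds alone.

Measured so far:
- compound 1, `CC(C)C[C@@H](C(=O)N[C@H](C(N)=O)C(C)(C)C)[C@H](C)N(O)C=O`: 33 nM
- compound 2, `CC[C@H](C)[C@H](NC(=O)[C@H](CC(C)C)[C@H](C)N(O)C=O)C(=O)Nc1nccs1`: 29 nM

In an assay on isolated protein for inhibition of matrix metalloproteinase-9 (Homo sapiens) (on this read-out lower numbers stand for stronger inhibition and higher numbers for weaker inhibition), compound 1 gives 33 nM. Compound 2 gives 29 nM in this assay. Of the two numbers, that of compound 2 is the lower, but the gap to compound 1 lies within the scatter, so the two compounds are not separated by these data.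

Compound 3, `CC(C)C[C@H](NC(=O)[C@H](CC(C)C)[C@H](C)N(O)C=O)C(=O)Nc1nccs1`, is not yet measured in this assay. It keeps the core and the thiazolyl amide of compound 2 and differs from it only in the change (isobutyl in place of sec-butyl on a saturated chain carbon bound to an amide-type nitrogen and a carbonyl carbon). The two structures hold the same atoms, joined differently. Among the compounds with values here, no step between measured compounds shows what this exchange does on this read-out, so no direction can be drawn from the series. The expectation is a step from compound 2 to compound 3 of a 1.2-fold higher number from compound 2 to compound 3 (0.08 log units; within the scatter), that is, no change beyond the scatter. Compound 3 is therefore estimated at 35 nM, with a range from 12 nM to 100 nM.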

Compound 3, inhibition constant: 17 nM
Compound 3: middle estimate off by 2.1-fold (0.31 log units), on the high side; low and high end bracket the measured number.
By their numbers in this assay, from the lowest: compounds 3, 2 and 1 (each within the scatter of the next).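

In this assay, within the data shown here, the exchange of sec-butyl for isobutyl on a saturated chain carbon bound to an amide-type nitrogen and a carbonyl carbon gives a 1.7-fold lower number from compound 2 to compound 3 (0.23 log units; within the scatter) and is the first step that can be read at this place. The two chains hold the same heavy atoms with a different branching, and the defined stereocentre of sec-butyl leaves with the exchange, yet the two compounds are not separated. For this pair, neither the shift in branching nor the loss of that stereocentre moves the read-out beyond the scatter.

From the compounds shown here alone, whether a shorter chain such as ethyl, a benzyl group or a chain carrying an amine would also stay within the scatter at this place remains open. No data at hand bear on why these two chains read alike.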